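Trifluoromethoxy for Hydrogen on an Arylpiperazine Aorta Antagonist

The source may hold more compounds than are shown below. What is called first, only, known or untested is meant among the compounds shown, and "the series" means these compounds.

Compounds measured so far:
compound 1, `COc1ccccc1N1CCN(CCCNc2ncccc2C(=O)NC(C)(C)C)CC1`, 10 nM
compound 2, `COc1ccccc1N1CCN(CCCNc2ccc(C(=O)N(C)C)cn2)CC1`, 31.6 nM
compound 3, `CN(C)C(=O)c1cccnc1NCCCN1CCN(c2ccccc2)CC1`, 15.9 nM

The three compounds share a phenylpiperazine joined through a three-carbon chain to an aminopyridine carboxamide, and all three were tested in a functional assay on aorta for antagonist activity at Alpha-1D adrenergic receptor (Rattus norvegicus); a higher number here means weaker binding, a lower number tighter binding. Compound 3 sits second highest among the three numbers with 15.9 nM. Its nearest neighbour is compound 1 with 10 nM, and the furthest is compound 2 with 31.6 nM; both of these gaps lie within the usual scatter of the assay, so the three compounds cannot be ranked against each other on these data.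

Compound 4 is `CN(C)C(=O)c1cccnc1NCCCN1CCN(c2ccccc2OC(F)(F)F)CC1`, not yet measured. It differs from compound 3 in one place: trifluoromethoxy in place of hydrogen on an aromatic carbon. For the measured compounds named here, no pair of measured compounds differs by this single change, so the size of the step has to be judged from the structures alone. With compound 1 and compound 2 carrying a methoxy at the same position and giving numbers close to those of compound 3, the expectation is for a small step, if any, in this assay; a change beyond the scatter in either direction is not expected.

Compound 4 is therefore estimated at 12 nM, within a range of 4 nM to 40 nM, which corresponds to an expected step of a 1.3-fold lower number from compound 3 to compound 4 (0.12 log units; within the scatter).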

Compound 4, dissociation constant: 100 nM
The estimate for compound 4 lay 8.3-fold (0.92 log units) below the measured number; measured number above the stated range.
By their numbers in this assay, from the lowest: compounds 1, 3 and 2 (each within the scatter of the next, the first and the last beyond it); then compound 4.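

In this assay, for the compounds shown here, trifluoromethoxy in place of hydrogen on an aromatic carbon, ortho to a large group, gives a 6.3-fold higher number from compound 3 to compound 4 (0.80 log units; beyond the scatter), the first step in this set that can be read for a single change. It shows that this place on the six-membered aromatic ring of carbon only is sensitive to what it carries, which compound 1 and compound 2 could not show, since each differs from compound 3 in more than one place and their methoxy group therefore cannot be read on its own. Nothing in the data shown accounts for the size of this step.

As far as these compounds go, it remains open whether a single fluorine atom, a chlorine atom, a hydroxyl or a methoxy group in place of the same hydrogen on compound 3 would give a similar step, or whether the step belongs to trifluoromethoxy in particular. Also open, from the compounds shown here alone, is whether trifluoromethoxy at this place would give a step of similar size with a different amide, such as the tert-butyl amide of compound 1, or on the other carbons of the same ring.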